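This account rests on a few compounds, and the source may have more. Where it says the series, first, only, none or still open, it means among the compounds named here.

Working notes on the series. In an assay on isolated protein (Oryctolagus cuniculus) with Thromboxane-A synthase (Homo sapiens) as the target, tested at 1 uM (a lower number here means less inhibition, a higher number more inhibition at the concentration tested (going by the name of the read-out)), compound 1 `O=c1c2ccccc2c(-c2cccnc2)nn1C1CCCC1` gives 97%, compound 2 `COCCn1nc(-c2cccnc2)c2ccccc2c1=O` gives 55% and compound 3 `O=C(c1cccs1)n1nc(-c2cccnc2)c2ccccc2c1=O` gives 37%. Compound 2 stands second highest of the three: the step of a number 42 percentage points lower from compound 1 to compound 2 (beyond the scatter) and the step of a number 18 percentage points lower from compound 2 to compound 3 (beyond the scatter) both lie beyond the scatter, as does a number 60 percentage points lower from compound 1 to compound 3 (beyond the scatter). Compound 4 `CC(C)NC(=O)CCCn1nc(-c2cccnc2)c2ccccc2c1=O` awaits measurement in this assay. Its change from compound 2 is (isopropylcarbamoyl)methyl in place of methoxy on a saturated chain carbon, two bonds along the chain from an aromatic nitrogen. The measured steps all exchange the whole substituent on the aromatic nitrogen, whereas this change alters the chain beyond it, so they bear on it only loosely; each such exchange moved the read-out, the nearer one modestly. A modest step downward is expected, a number 10 percentage points lower from compound 2 to compound 4 (within the scatter). Compound 4 is therefore estimated at 45%, within 20% to 70%.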

Compound 4, a percentage reported as inhibition, at one concentration (the size of the read-out at that concentration, not a potency): 89%
Compound 4: middle estimate off by 44 percentage points, on the low side; measured number above the stated range.
By their numbers in this assay, from the lowest: compound 3; then compound 2; then compounds 4 and 1 (each within the scatter of the next).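

The step of a number 34 percentage points higher from compound 2 to compound 4 (beyond the scatter) shows that a change in the chain beyond the aromatic nitrogen, with that nitrogen's first carbons kept, can alone move the read-out by a large amount. It also shows that an open-chain substituent can match a ring: compound 4 and compound 1 lie within the scatter of each other in this assay. No measurement at hand accounts for the step. Still open, going by these compounds, is whether the amide or the added chain length carries the gain. A carboxylic acid or a plain longer chain at this place would separate the two.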